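This account rests on a few compounds, and the source may have more. Where it says the series, first, only, none or still open, it means among the compounds named here.

Values in a functional assay on HCC 2998 cells (Homo sapiens) for antiproliferative activity, read by sulforhodamine B assay, with a stated time of 48 h; a lower number here means a stronger inhibitor, a higher number a weaker inhibitor:
- compound 1 `C/C=C(\C)C(=O)O[C@H]1C=CC(=O)O[C@H]1CCC(=O)[C@H](C)O`: 18000 nM
- compound 2 `C/C=C(\C)C(=O)O[C@H]1C=CC(=O)O[C@H]1COC(=O)[C@H](C)O`: 11000 nM
- compound 3 `C/C=C(\C)C(=O)O[C@H]1C=CC(=O)O[C@H]1CNC(=O)[C@H](C)O`: not yet measured

Compound 2 stands within the scatter of compound 1. The change to compound 3 is ((1-hydroxyethyl)carbonyl)amino in place of ((1-hydroxyethyl)carbonyl)oxy on a saturated chain carbon bound to a saturated ring carbon. For the measured compounds named here, the only measured step at this place is a 1.6-fold lower number from compound 1 to compound 2 (0.21 log units; within the scatter), which put ((1-hydroxyethyl)carbonyl)oxy in place of ((1-hydroxyethyl)carbonyl)methyl. On that single step, no change beyond the scatter is expected in this assay, in either direction. The estimated step is a 1.3-fold higher number from compound 2 to compound 3 (0.10 log units; within the scatter). For compound 3 the expected value is 14000 nM, with an estimated range of 6000 nM to 32000 nM.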

Compound 3, half-maximal inhibitory concentration: 25000 nM
The estimate for compound 3 lay 1.8-fold (0.25 log units) below the measured number; low and high end bracket the measured number.
By their numbers in this assay, from the lowest: compounds 2, 1 and 3 (each within the scatter of the next, the first and the last beyond it).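

In this assay, for the compounds shown here, ((1-hydroxyethyl)carbonyl)amino in place of ((1-hydroxyethyl)carbonyl)oxy on a saturated chain carbon bound to a saturated ring carbon gives a 2.3-fold higher number from compound 2 to compound 3 (0.36 log units; beyond the scatter) as the first step at this place to pass the scatter, though only modestly. Against ((1-hydroxyethyl)carbonyl)methyl, the same group gives a 1.4-fold higher number from compound 1 to compound 3 (0.14 log units; within the scatter) and is not told apart from it. Nothing measured here accounts for these steps. Going by these compounds, whether a carboxylic acid or a longer chain in place of the 1-hydroxyethyl would shift the number at this place remains open.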